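A few compounds are considered here, and "the series" means these few. Any claim that something is new, unique, unknown or untested is made for them only; others in the source may bear on it.

Compound 1 `O=C(CSc1nc(Nc2ccccc2)c2ccccc2n1)Nc1cccc(Br)c1` gives 10100 nM in a functional assay on NCI-H1975 cells (Homo sapiens) for inhibition, read by MTT assay, with a stated time of 72 h; on this read-out higher numbers stand for weaker inhibition and lower numbers for stronger inhibition. Compound 2 `O=C(CSc1nc(Nc2ccccc2)c2ccccc2n1)Nc1cccc([N+](=O)[O-])c1` gives 17900 nM in this assay. Compound 3 `C=CC(=O)Nc1cccc(NC(=O)CSc2nc(Nc3cccc(Br)c3)c3ccccc3n2)c1` gives 12100 nM in this assay.

Compound 2 differs from compound 1 in one place, (nitro in place of bromo on an aromatic carbon), and this step made a 1.8-fold higher number from compound 1 to compound 2 (0.25 log units; within the scatter). Compound 3 carries a different core; the difference between the core of compound 1 and the core of compound 3 is not broken down here, and its value sits close to those of compound 1 and compound 2.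

Compound 4 `C=CC(=O)Nc1cccc(NC(=O)CSc2nc(Nc3cccc([N+](=O)[O-])c3)c3ccccc3n2)c1` has not yet been measured. It differs from compound 3 by nitro in place of bromo on an aromatic carbon, which is the same change that turns compound 1 into compound 2, at the same kind of place. Because that step gave a 1.8-fold higher number from compound 1 to compound 2 (0.25 log units; within the scatter), the step from compound 3 to compound 4 is expected to be of similar size, a 1.7-fold higher number from compound 3 to compound 4 (0.22 log units; within the scatter), resting on a single earlier pair only. On that basis compound 4 is estimated at 20000 nM in this assay, with an expected range from 9000 nM to 45000 nM.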

Compound 4, half-maximal inhibitory concentration: 22600 nM
Estimate against measurement, compound 4: 1.1-fold (0.05 log units) below; the measured number falls inside the stated range.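

In this assay, nitro in place of bromo on an aromatic carbon gave a 1.9-fold higher number from compound 3 to compound 4 (0.27 log units; within the scatter), and beside the earlier step the change carried from one core to the other with no difference that can be told apart: the same change on two cores in this assay, a 1.8-fold higher number (0.25 log units; within the scatter) from compound 1 to compound 2 and a 1.9-fold higher number (0.27 log units; within the scatter) from compound 3 to compound 4, 1.1-fold (0.02 log units) apart, within the scatter of two such steps. Both steps lie within the scatter, so the agreement is one between two small steps and does not show that nitro and bromo truly differ on this read-out. Two pairs on two cores also say nothing about how the change would behave on a further core, and they give no explanation for the agreement.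

As far as these compounds go, it remains open whether an amine or a carboxylic acid in place of the bromo or nitro would move the number beyond the scatter on either core. From the compounds shown here alone, it is equally open whether such a replacement would give steps of similar size on the two cores, as this one does.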